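The compounds below may be only part of what the source reports. "The series", "measured", "known", "first", "only" and "open" are said of these compounds alone.

Compound 1 `CS(=O)(=O)c1ccc(-c2[nH]c(S(C)(=O)=O)cc2-c2ccc(F)cc2)cc1`: 93 uM
Compound 2 `CS(=O)(=O)c1ccc(-c2[nH]c(I)c(I)c2-c2ccc(F)cc2)cc1`: 72.8 uM
Compound 3 `CS(=O)(=O)c1ccc(-c2[nH]c(Br)c(Cl)c2-c2ccc(F)cc2)cc1`: 9.98 uM

In a functional assay on the whole organism with Rattus norvegicus as the target (on this read-out higher numbers stand for an effect only at larger amounts of compound and lower numbers for an effect already at smaller amounts), compound 1 stands at the high end of the three numbers, within the scatter of compound 2, while compound 3 lies clearly lower. Compound 4 `CS(=O)(=O)c1ccc(-c2[nH]c(Cl)cc2-c2ccc(F)cc2)cc1` has chloro in place of methylsulfonyl on an aromatic carbon, next to the ring nitrogen (chloro in place of methylsulfonyl on an aromatic carbon). Among the compounds with values here, no two measured compounds differ in one place alone, so the evidence is indirect. Halogens appear on the core in both compound 2 (72.8 uM) and compound 3 (9.98 uM), which makes them only a loose guide. A moderately lower number is expected, with a 3.7-fold lower number from compound 1 to compound 4 (0.57 log units; beyond the scatter) as the estimated step. For compound 4 the estimated value is 25 uM with 7 uM to 80 uM as the expected range.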

Compound 4, concentration for half-maximal effect: 1.43 uM
Compound 4: middle estimate off by 17-fold (1.24 log units), on the high side, and the stated range ends above it.
By their numbers in this assay, from the lowest: compound 4; then compound 3; then compounds 2 and 1 (each within the scatter of the next).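

In this assay, replacing methylsulfonyl with chloro at this position, on the aromatic carbon next to the ring nitrogen, gives a large change (a 65-fold lower number from compound 1 to compound 4 (1.81 log units; beyond the scatter)). Within the data shown here, this single swap isolates the position, which the earlier compounds could not do, and shows that the group held here can strongly shift the concentration needed for an effect. Nothing measured here explains the size of this step.

From the compounds shown here alone, it remains open whether the change comes from losing methylsulfonyl or from gaining chloro. A methyl, a nitrile or a simple hydrogen at this position would help separate the two.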